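Swapping the ring on the carbonyl of a weak compound

This account rests on a few compounds, and the source may have more. Where it says the series, first, only, none or still open, it means among the compounds named here.

Measured so far:
- Compound 1 `CCC(=O)N1CCc2nc(C#Cc3ccccc3)sc2C1`: 38 nM
- Compound 2 `O=C(C1CCOCC1)N1CCc2nc(C#Cc3ccccc3)sc2C1`: > 10000 nM, a limit of the assay

Compound 1 carries an ethyl group on its carbonyl carbon and, in an assay on HEK293 cells for negative allosteric modulation of metabotropic glutamate receptor 5 (Homo sapiens), read by FLIPR, with a stated time of 1 h (on this read-out lower numbers stand for stronger inhibition and higher numbers for weaker inhibition), compound 1 gives 38 nM. Compound 2 has an oxan-4-yl group in that place instead. In this assay compound 2 gives > 10000 nM, which is a limit of the assay and not a number. Compound 2 reaches only the limit (the limit of > 10000 nM in this assay, at which 1 of the 2 values shown sits), which is not a number but the edge of what the assay reports. The step of an at least 260-fold higher number from compound 1 to compound 2 (2.42 log units; beyond the scatter) therefore shows a large loss of inhibition.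

Compound 3 `O=C(N1CCC(F)CC1)N1CCc2nc(C#Cc3ccccc3)sc2C1` has not been measured. It differs from compound 2 in one place: 4-fluoropiperidin-1-yl in place of oxan-4-yl on a carbonyl carbon. Among the measured compounds shown here, only one measured step bears on this change, and it is the one from compound 1 to compound 2, which was large. Compound 2 itself stands at a limit, so the direction of the step to compound 3 cannot be read from a number. Compound 3 is expected to stay near that limit, with the step of an at least 1.2-fold lower number from compound 2 to compound 3 (0.09 log units; that floor lies within the scatter) as an estimate. Compound 3 is thus estimated at 8000 nM, within a range from 1500 nM to 30000 nM.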

Compound 3, half-maximal inhibitory concentration: > 10000 nM
Compound 3 was reported as a limit; the forecaster's own chance of this, stated with the estimate: 55%; at least 1.2-fold (0.09 log units) between middle value and limit.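

In this assay, putting 4-fluoropiperidin-1-yl on the carbonyl carbon in place of ethyl brings an at least 260-fold higher number from compound 1 to compound 3 (2.42 log units; beyond the scatter), so the large loss of inhibition seen earlier is not peculiar to oxan-4-yl. Two different six-membered non-aromatic rings now stand in this place, and neither keeps the inhibition that compound 1 shows with its ethyl group; exchanging the ring oxygen of oxan-4-yl for the nitrogen and fluorine of the new group does not bring inhibition back into a readable range. Compound 2 and compound 3 both stand at the limit of the assay, which is not a number, so the step between them cannot be read and neither can be ranked against the other: the limit of > 10000 nM in this assay, at which 2 of the 3 values shown sit.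

The compounds shown leave open where, on the way from ethyl to these rings, inhibition is lost, since only one group in this place gives a readable value. A small ring such as cyclopropyl, a longer chain such as butyl, or an open-chain amine such as dimethylamino on the carbonyl carbon could each help to answer that.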